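This account rests on a few compounds, and the source may have more. Where it says the series, first, only, none or still open, it means among the compounds named here.

Compound 2 `C=CCCC1CNC1=O` is the lower of the two compounds measured in an assay for inhibition of Fatty-acid amide hydrolase 1 (Homo sapiens), tested at 1 mM (on this read-out lower numbers stand for less inhibition and higher numbers for more inhibition at the one concentration tested (going by the name of the read-out)), where compound 2 gives 48%. Its nearest neighbour is compound 1 `C=CCCCC1CNC1=O`, which in this assay gives 80.9%. The only difference between these two lies in the side chain, and the step of a number 32.9 percentage points lower from compound 1 to compound 2 (beyond the scatter) was large. Compound 3 `C=CCC1CNC1=O` is the next member of the same series, shortening the chain once more: vinyl in place of allyl on a saturated chain carbon bound to a saturated ring carbon. For the measured compounds named here, the one measured step bearing on this, from compound 1 to compound 2, removed the same carbon count from the same chain and cost a large amount of inhibition, so a further drop beyond the scatter is expected in this assay, meaning a step of a number 28 percentage points lower from compound 2 to compound 3 (beyond the scatter) from compound 2 to compound 3. Compound 3 is therefore estimated at 20%, in the range 5% to 40%.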

Compound 3, a percentage reported as inhibition, at one concentration (the size of the read-out at that concentration, not a potency): 56.6%
Compound 3: middle estimate off by 36.6 percentage points, on the low side, and the stated range ends below it.
By their numbers in this assay, from the lowest: compounds 2 and 3 (each within the scatter of the next); then compound 1.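

In this assay the exchange of vinyl for allyl on a saturated chain carbon bound to a saturated ring carbon gives a number 8.6 percentage points higher from compound 2 to compound 3 (within the scatter) and so makes no clear difference at this position. The same exchange on a saturated chain carbon, two bonds along the chain from a saturated ring carbon, gave a number 32.9 percentage points lower from compound 1 to compound 2 (beyond the scatter) and so shortening the chain does not cost inhibition evenly, and compound 3 goes against any steady fall with chain length. No measurement at hand says why these two steps differ so much.

The compounds shown leave open how a chain longer than that of compound 1 would read in this assay and whether the terminal double bond matters at all. They also leave open what a saturated propyl chain, or a chain carrying an amine or a carboxylic acid, would give.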